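The source may report more compounds than this note shows. Statements on the series, on what has been measured and on what is new or still open speak of the compounds shown alone.

Measured compounds:
compound 1 `CCc1cnc(N2CCC(c3nc(COc4ccc(/C=C5\CC(=O)NC5=O)cc4F)cs3)CC2)nc1` — 49 nM
compound 2 `CCc1cnc(N2CCC(c3nc(COc4ccc(/C=C/C(=O)O)cc4F)cs3)CC2)nc1` — "not determined" (no result reported)

Compound 2 stands nowhere on the numbers: in a functional assay on cells for agonist activity at Glucose-dependent insulinotropic receptor (Homo sapiens), read by a luciferase reporter, with a stated time of 6 h (on this read-out higher numbers stand for an effect only at larger amounts of compound and lower numbers for an effect already at smaller amounts), compound 2 has no result, so its position relative to compound 1 cannot be stated. Compound 1, in this assay, gives 49 nM, the only measured point in the series.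

Compound 3 `CCc1cnc(N2CCC(c3nc(COc4ccc(/C=C5\CCNC5=O)cc4F)cs3)CC2)nc1` differs from compound 2 by a group of 7 heavy atoms (5 carbon, 1 nitrogen, 1 oxygen; one five-membered non-aromatic ring with 1 hetero atom) in place of a group of 5 heavy atoms (3 carbon, 2 oxygen; no ring), on an aromatic carbon. With no value for compound 2, no size or direction of step from compound 2 to compound 3 can be stated, and none is claimed here.

The expectation for compound 3 rests on compound 1 alone, whose five-membered ring group on the same aromatic carbon is the closest measured analogue. Compound 3 is estimated to give 150 nM in this assay, with a range of 30 nM to 800 nM, because compound 1 gives 49 nM.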

Compound 3, half-maximal effective concentration: 100 nM
For compound 3 the middle estimate is 1.5-fold (0.18 log units) above the measured one; measured number inside the range.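

In this assay, the aromatic carbon meta to a fluoro group and para to a large group keeps agonist activity when the five-membered ring group loses a carbonyl, with a 2.0-fold higher number from compound 1 to compound 3 (0.31 log units; beyond the scatter). Among these compounds, this modest step is the first reading of how this position responds to a change within the ring group, and it shows that the second ring carbonyl of compound 1 is not required for a measurable effect. The step from compound 2 to compound 3 cannot be read, so the 2-carboxyethenyl group has no place relative to either ring group, and no measurement on hand explains the step from compound 1 to compound 3.

Still open, as far as these compounds go, is how an open-chain amide or an amine on the same aromatic carbon would compare with these ring groups. Also open, from the compounds shown here alone, is whether a six-membered lactam at this position would follow the same trend.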